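A few compounds are considered here, and "the series" means these few. Any claim that something is new, unique, unknown or untested is made for them only; others in the source may bear on it.

Compound 1 `C/C(=N\NC(=O)c1ccc(C(F)(F)F)cc1)c1cnccn1` is the reference point of this small set. In an ADME assay on cells (Homo sapiens) for antiproliferative activity, read by MTT assay (a lower number here means a stronger inhibitor, a higher number a weaker inhibitor), compound 1 gives 1160 nM. Among the measured compounds shown here, compound 2 `C/C(=N\NC(=O)c1ccc(N)cc1)c1cnccn1` carries the one change described as amino in place of trifluoromethyl on an aromatic carbon, and in this assay compound 2 gives 58800 nM; the step of a 51-fold higher number from compound 1 to compound 2 (1.70 log units; beyond the scatter) is large and lies beyond the scatter. Compound 3 `O=C(N/N=C/c1ccccn1)c1ccc(C(F)(F)F)cc1` has a different core from compound 1, and the difference between the two cores is not broken down here; in this assay compound 3 gives 22400 nM, the second highest of the three numbers, nearer to compound 2 than to compound 1. Compound 4 `Nc1ccc(C(=O)N/N=C/c2ccccn2)cc1` has not yet been measured. It differs from compound 3 by amino in place of trifluoromethyl on an aromatic carbon, the same change that separates compound 1 from compound 2, made at the same kind of place. Because the earlier step of a 51-fold higher number from compound 1 to compound 2 (1.70 log units; beyond the scatter) was large, a step of the same direction and comparable size is expected for compound 4, namely an 18-fold higher number from compound 3 to compound 4 (1.25 log units; beyond the scatter). Compound 4 is therefore estimated at 400000 nM, within a range from 80000 nM to 2000000 nM, though a number this high may be reported only as a limit of the assay.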

Compound 4, half-maximal inhibitory concentration: > 80000 nM
Compound 4: a limit, no number; the forecaster's own chance of this, stated with the estimate: 50%; the middle value is on the limit's open side.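

In this assay, amino in place of trifluoromethyl again gives a weaker inhibitor on the second core, an at least 3.5-fold higher number from compound 3 to compound 4 (0.55 log units; beyond the scatter), so the change goes the same way on the core of compound 1 and on the core of compound 3. Compound 4 gives a limit of the assay and not a number: the limit of > 80000 nM in this assay, at which 1 of the 4 values shown sits. This shows the direction of the change carrying over between the two cores, but it does not show whether the size carries over as well: the same change on two cores in this assay, a 51-fold higher number (1.70 log units; beyond the scatter) from compound 1 to compound 2 and an at least 3.5-fold higher number (0.55 log units; beyond the scatter) from compound 3 to compound 4; the limit leaves it open whether they differ.

The compounds shown hold only trifluoromethyl and amino at this place, so it stays open how a chlorine, a methoxy group or a nitrile would read there on either core. Compound 1 and compound 3 also differ in their cores, and the compounds shown do not break that difference down into its parts, so it remains open which part of it goes with the gap between their values.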